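The compounds below may be only part of what the source reports. "The series", "measured", "known", "first", "only" and "open" are said of these compounds alone.

Compound 3 `N=C(NCCCc1c[nH]cn1)NCCC(c1ccc(C(F)(F)F)cc1)c1ccccn1` sits at 282 nM in a functional assay on ileum for antagonist activity at histamine H1 receptor (Cavia porcellus) (a higher number here means weaker binding, a lower number tighter binding), the highest of the three numbers measured; compound 2 `N=C(NCCCc1c[nH]cn1)NCCC(c1ccc(Cl)cc1)c1ccccn1` gives 77.6 nM and compound 1 `N=C(NCCCc1c[nH]cn1)NCCCC(c1ccc(F)cc1)c1ccccn1` gives 46.8 nM. Compound 4 `N=C(NCCCc1c[nH]cn1)NCCC(c1cc(F)cc(F)c1)c1ccccn1` differs from compound 3 by 3,5-difluorophenyl in place of 4-(trifluoromethyl)phenyl on a saturated chain carbon bound to an aromatic carbon and a saturated chain carbon. Among the measured compounds shown here, the only measured step that bears on this aryl substituent is a 3.6-fold higher number from compound 2 to compound 3 (0.56 log units; beyond the scatter), where the trifluoromethyl group raised the number. Compound 4 removes that trifluoromethyl group and carries two fluorines instead, so the step in this assay is expected to run back downward; the estimated step is a 2.8-fold lower number from compound 3 to compound 4 (0.45 log units; beyond the scatter). Compound 4 is therefore expected to give about 100 nM in this assay, with a likely range from 40 nM to 250 nM.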

Compound 4, dissociation constant: 275 nM
Compound 4: middle estimate off by 2.8-fold (0.44 log units), on the low side; the measured number lies above the stated range.
By their numbers in this assay, from the lowest: compounds 1 and 2 (each within the scatter of the next); then compounds 4 and 3 (each within the scatter of the next).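

In this assay, 3,5-difluorophenyl in place of 4-(trifluoromethyl)phenyl gives a 1.0-fold lower number from compound 3 to compound 4 (0.01 log units; within the scatter) and so the two groups cannot be told apart at this position. In place of 4-chlorophenyl, the same group gives a 3.5-fold higher number from compound 2 to compound 4 (0.55 log units; beyond the scatter) and thus runs the same way as the trifluoromethyl step, leaving 4-chlorophenyl apart from both. Nothing at hand says why these two groups read alike.

As far as these compounds go, whether an unsubstituted phenyl or a 4-methoxyphenyl on this carbon would read with compound 2 or with compound 3 stays open. So does how a single fluorine would read here.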